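The source may report more compounds than this note shows. Statements on the series, on what has been measured and on what is new or still open speak of the compounds shown alone.

Compound 1 `O=C(O)CC/C=C\CC1COC(c2cccs2)OC1c1cccnc1`: 1000 nM
Compound 2 `O=C(O)CC/C=C\CC1COC(c2cccc3ccccc23)OC1c1cccnc1`: 631 nM
Compound 3 `CSc1ccccc1OC(C)(C)C1OCC(C/C=C\CCC(=O)O)C(c2cccnc2)O1`: 89.1 nM

All three compounds were measured in a functional assay for inhibition, with Homo sapiens as the target; on this read-out lower numbers stand for tighter binding and higher numbers for weaker binding. Compound 3 has the lowest number of the three at 89.1 nM, and its gaps to compound 2 and compound 1 both lie beyond the usual scatter.

Compound 4 `CC(C)(Cc1ccccc1)C1OCC(C/C=C\CCC(=O)O)C(c2cccnc2)O1` has not yet been measured. It differs from compound 3 in one place: benzyl in place of 2-(methylsulfanyl)phenoxy on a saturated chain carbon bound to two saturated chain carbons and a saturated ring carbon. In words, this is benzyl in place of 2-(methylsulfanyl)phenoxy on a saturated chain carbon bound to two saturated chain carbons and a saturated ring carbon.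

Within the data shown here, only one measured step involves swapping one single group for another: a 1.6-fold lower number from compound 1 to compound 2 (0.20 log units; within the scatter). That step lies within the scatter, but it sits at a different place in the molecule, so it is only a loose guide. Among the measured compounds shown here, no measured step changes the group on this chain carbon, so the data cannot fix a direction firmly. Compound 3 at 89.1 nM is already the lowest of the set, so a moderate move towards a higher number seems the more likely outcome in this assay. The expected change is a 2.0-fold higher number from compound 3 to compound 4 (0.31 log units; beyond the scatter). Compound 4 is expected at about 180 nM, with an estimated range from 60 nM to 550 nM.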

Compound 4, dissociation constant: 513 nM
The estimate for compound 4 lay 2.9-fold (0.45 log units) below the measured number; the measured number falls inside the stated range.
By their numbers in this assay, from the lowest: compound 3; then compounds 4, 2 and 1 (each within the scatter of the next).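

In this assay, among these compounds, the change at this saturated chain carbon gives a 5.8-fold higher number from compound 3 to compound 4 (0.76 log units; beyond the scatter), beyond the scatter, which is the first sign that the group here can shift the number by a clear margin. Both 2-(methylsulfanyl)phenoxy and benzyl carry one six-membered aromatic ring of carbon only, so that ring alone does not keep the number as low as in compound 3; the oxygen and sulfur atoms are what leave, and the group shrinks from 9 heavy atoms to 7. The benzyl compound also loses its edge over the earlier ring substituents, with a 1.2-fold lower number from compound 2 to compound 4 (0.09 log units; within the scatter) and a 1.9-fold lower number from compound 1 to compound 4 (0.29 log units; within the scatter), both within the scatter, so 1-benzyl-1-methylethyl on the saturated ring carbon reads the same as naphthalen-1-yl or thiophen-2-yl there.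

No measurement shown accounts for the size of this step. The compounds shown do not separate the oxygen from the methylsulfanyl group, so it stays open which of the two carries the gap; an unsubstituted phenoxy and a methoxy group in place of methylsulfanyl would each test one part of that question.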